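Trifluoromethyl for methyl on the phenoxy ring

The compounds below may be only part of what the source reports. "The series", "measured", "known", "first", "only" and "open" are said of these compounds alone.

Measured compounds:
compound 1 `Clc1ccc(OC(CCn2ccnc2)c2ccccc2)c(Cl)c1` gives 96700 nM
compound 2 `Cc1ccc(OC(CCn2ccnc2)c2ccccc2)cc1` gives 95900 nM
compound 3 `Fc1ccc(OC(CCn2ccnc2)c2ccccc2)c(F)c1` gives 298000 nM

All three share one core and differ only in the groups on the ring that carries the ether oxygen. In a functional assay on K562 cells (Homo sapiens) for cytotoxicity (a lower number here means that less compound is tolerated, a higher number that more compound is tolerated), compound 2 gives 95900 nM and compound 1 gives 96700 nM; these two numbers lie within the scatter of each other, so nothing separates them. Compound 3 gives 298000 nM, a higher number that lies beyond the scatter, meaning more of compound 3 is tolerated by the cells than of compound 2.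

Compound 4 `FC(F)(F)c1ccc(OC(CCn2ccnc2)c2ccccc2)cc1` has not been measured. It differs from compound 2 in one place: trifluoromethyl in place of methyl on an aromatic carbon. Going by the values given here, no pair of measured compounds shows what such a swap does here, so no measured step can be leaned on. Given that compound 1 and compound 2 sit together while only compound 3 stands apart, the change is expected to move the number little, with a slight lean toward a lower value. For compound 4 the estimate in this assay is 70000 nM, within a range from 30000 nM to 200000 nM, which amounts to an expected step of a 1.4-fold lower number from compound 2 to compound 4 (0.14 log units; within the scatter).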

Compound 4, half-maximal cytotoxic concentration: 71000 nM
Compound 4: the middle estimate sits 1.0-fold (0.01 log units) below what was measured; the measured number falls inside the stated range.
By their numbers in this assay, from the lowest: compounds 4, 2 and 1 (each within the scatter of the next); then compound 3.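

In this assay, putting trifluoromethyl in place of methyl on this aromatic carbon, para to a large group, gives a 1.4-fold lower number from compound 2 to compound 4 (0.13 log units; within the scatter). Going by these compounds alone, this is the first step that changes one place only, so it offers a direct reading that the earlier compounds could not: going from a group of 1 heavy atom to one of 4 heavy atoms at this position leaves no difference that can be told from the scatter of repeated measurements. The two groups therefore cannot be separated in this cell assay, and nothing measured here explains why they read alike.

As far as these compounds go, a single swap says little about the position as a whole, so it remains open whether an amine, a carboxylic acid or a longer chain on this same aromatic carbon would shift the number beyond the scatter. From the compounds shown here alone, it also remains open whether methyl and trifluoromethyl would stay this close on the shared core if the other ring carried a chlorine or a fluorine in place of its hydrogen.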